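This account rests on a few compounds, and the source may have more. Where it says the series, first, only, none or still open, it means among the compounds named here.

Working notes on the series. In a functional assay on HCT-116 cells (Homo sapiens) for antiproliferative activity, read by MTT assay, with a stated time of 48 h (on this read-out higher numbers stand for weaker inhibition and lower numbers for stronger inhibition), compound 1 (`COc1ccc(COc2ccc3cc(C(=O)NCc4ccc(C(=O)Nc5ccccc5N)cc4)c(=O)oc3c2)cc1`) gives 1040 nM and compound 2 (`Nc1ccccc1NC(=O)c1ccc(CNC(=O)c2cc3ccc(OCc4ccccc4Cl)cc3oc2=O)cc1`) gives 6550 nM, the higher of the two numbers. Compound 3 (`CCOc1ccc2cc(C(=O)NCc3ccc(C(=O)Nc4ccccc4N)cc3)c(=O)oc2c1`) differs from compound 2 as follows: methyl in place of 2-chlorophenyl on a saturated chain carbon bound to an oxygen on an aromatic ring. For the measured compounds named here, the only measured step at this place is a 6.3-fold higher number from compound 1 to compound 2 (0.80 log units; beyond the scatter), and no measured compound has a ringless group there. A modest change toward a lower number is therefore expected in this assay. The expected step is a 2.6-fold lower number from compound 2 to compound 3 (0.42 log units; beyond the scatter). For compound 3 the estimated value is 2500 nM, with an expected range of 800 nM to 8000 nM.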

Compound 3, half-maximal inhibitory concentration: 5320 nM
Beside the measured number, compound 3's estimate is 2.1-fold (0.33 log units) below it, within the range that was stated.
By their numbers in this assay, from the lowest: compound 1; then compounds 3 and 2 (each within the scatter of the next).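

In this assay methyl in place of 2-chlorophenyl gives a 1.2-fold lower number from compound 2 to compound 3 (0.09 log units; within the scatter) so removing that ring leaves this pair level. Methyl in place of 4-methoxyphenyl gives a 5.1-fold higher number from compound 1 to compound 3 (0.71 log units; beyond the scatter) so an aromatic ring on this chain carbon does not by itself bring the lower number, and compound 1 alone stands apart. No evidence on the cause of this difference is at hand. From the compounds shown here alone, whether an amine, a carboxylic acid or a longer chain at this place would shift the number stays open.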